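Methyl in place of hydrogen on the core of compound 2

The compounds below may be only part of what the source reports. "The series", "measured", "known", "first", "only" and "open" are said of these compounds alone.

Measured so far:
compound 1 `O=C(Nc1cc(C(F)(F)F)cc(C(F)(F)F)c1)c1nsnc1O`: > 100000 nM
compound 2 `Cn1cc(C(=O)Nc2cc(C(F)(F)F)cc(C(F)(F)F)c2)c(O)n1`: > 100000 nM

In an assay on isolated protein for inhibition of mitogen-activated protein kinase kinase kinase 14 (Homo sapiens), read by ADP-Glo, with a stated time of 60 min, in the presence of a further agent that is not named here (on this read-out lower numbers stand for stronger inhibition and higher numbers for weaker inhibition), compound 1 gives > 100000 nM, which is a limit of the assay. Compound 2 gives > 100000 nM, likewise a limit. The step that the two limits leave unreadable from compound 1 to compound 2 is thus unreadable, both values sitting at the same limit (the limit of > 100000 nM in this assay, at which 2 of the 2 values shown sit). Compound 2 therefore stands at the limit, with no number of its own. Compound 3 `Cc1c(C(=O)Nc2cc(C(F)(F)F)cc(C(F)(F)F)c2)c(O)nn1C` differs from compound 2 by methyl in place of hydrogen on an aromatic carbon. No measured step bears on this change, and the single step shown gives no readable size at all. Compound 3 is expected to stay at the limit as well, with an estimate of 100000 nM in a range from 30000 nM to 300000 nM. The expected step of a number no higher from compound 2 to compound 3 (the limit leaves the size open) is accordingly none beyond the scatter.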

Compound 3, half-maximal inhibitory concentration: > 100000 nM
Compound 3 ended at the assay's limit; the forecaster's own chance of this, stated with the estimate: 85%; the middle value sits exactly at the limit.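

Among the compounds shown here, compound 3 sits at the assay's limit, as do compound 1 and compound 2, so no step among them can be read: the limit of > 100000 nM in this assay, at which 3 of the 3 values shown sit. As far as these compounds go, whether methyl in place of hydrogen changes inhibition at all remains open, as does the true potency of all three compounds.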